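The source may report more compounds than this note shows. Statements on the series, on what has been measured and on what is new or still open speak of the compounds shown alone.

Compound 1 `Cc1ccc(C(=O)CCc2nnc(-c3ccc(Cl)cc3)o2)cc1`: 81.5%
Compound 2 `COc1ccc(-c2nnc(CCC(=O)c3ccc(C)cc3)o2)cc1`: 89.5%
Compound 3 `COc1ccc(-c2nnc(CCC(=O)c3ccc(C)cc3)o2)cc1OC`: 72.6%

In a functional assay on the whole organism (strain Wistar) for inhibition, with Rattus norvegicus as the target, with stated times of 30 min and 3 h, at a dose of 20 mg/kg by the oral route (a lower number here means less inhibition, a higher number more inhibition at the dose given (going by the name of the read-out)), compound 2 has the highest of the three numbers. Compound 1 sits close to it, the difference being a number 8 percentage points higher from compound 1 to compound 2 (within the scatter), while compound 3 lies further off, with a number 16.9 percentage points lower from compound 2 to compound 3 (beyond the scatter). Compound 4 `COc1ccc(-c2nnc(CCC(=O)c3ccc(C)cc3C)o2)cc1` departs from compound 2 by methyl in place of hydrogen on an aromatic carbon. Neither measured step touches this part of the shared core; both alter the other aromatic ring, so they bear only indirectly on the new change, and nothing in the data ties a methyl on this ring to a shift in inhibition. A step of at most modest size, in either direction, is therefore expected. For compound 4 the estimate is 84%, with a range from 65% to 97%, which amounts to an expected step of a number 5.5 percentage points lower from compound 2 to compound 4 (within the scatter).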

Compound 4, a percentage reported as inhibition, in the whole organism at one dose (the size of the read-out at that dose, not a potency): 88.9%
The estimate for compound 4 lay 4.9 percentage points below the measured number; low and high end bracket the measured number.
By their numbers in this assay, from the lowest: compounds 3, 1, 4 and 2 (each within the scatter of the next, the first and the last beyond it).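

Going from 4-methylphenyl to 2,4-dimethylphenyl, the only change on this ring among the compounds shown, gives in this assay a number 0.6 percentage points lower from compound 2 to compound 4 (within the scatter). A methyl ortho to a large group therefore leaves the inhibition at this dose within the scatter of the unsubstituted position, so this place accepts at least this one added carbon. Nothing measured here explains this result. From the compounds shown here alone, it remains open whether an ethyl, an amine or a carboxylic acid at the same place would also leave the number unchanged. A single oral dose also leaves open whether compound 2 and compound 4 would still match at other doses.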